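Urea series on the shared core: ethyl on the terminal phenyl

A few compounds are considered here, and "the series" means these few. Any claim that something is new, unique, unknown or untested is made for them only; others in the source may bear on it.

Measured compounds in a functional assay on HepG2 cells (Homo sapiens) for antiproliferative activity, read by MTT assay, with a stated time of 48 h; on this read-out higher numbers stand for weaker inhibition and lower numbers for stronger inhibition:
compound 1 `O=C(Nc1ccccc1)Nc1cccc(CNc2nccnc2Cl)c1` gives 15600 nM.
compound 2 `CN(C)c1ccc(NC(=O)Nc2cccc(CNc3nccnc3Cl)c2)cc1` gives only a limit, > 40000 nM.
compound 3 `O=C(Nc1cccc(CNc2nccnc2Cl)c1)NC1CCCC1` gives 18400 nM.

Compound 1 holds the lowest of the two numbers shown; compound 3 sits within the scatter of it, the step of a 1.2-fold higher number from compound 1 to compound 3 (0.07 log units; within the scatter) being cyclopentyl in place of phenyl on an amide-type nitrogen. Compound 2 sits at a limit of this assay (the limit of > 40000 nM in this assay, at which 1 of the 3 values shown sits). For the measured compounds named here, the step of an at least 2.5-fold higher number from compound 1 to compound 2 (0.40 log units; beyond the scatter), dimethylamino in place of hydrogen on an aromatic carbon, is the only measured change on the terminal phenyl, and it weakened inhibition; an at least 2.1-fold lower number from compound 2 to compound 3 (0.33 log units; beyond the scatter) runs back toward the numbers of compound 1 and compound 3.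

Compound 4 `CCc1ccccc1NC(=O)Nc1cccc(CNc2nccnc2Cl)c1` differs from compound 1 by ethyl in place of hydrogen on an aromatic carbon. Going by the values given here, no measured step adds ethyl at this place. The one substitution on this ring, compound 1 to compound 2, gave a weaker number, while the change at the amide-type nitrogen stayed within scatter. A small shift toward a higher number is therefore expected, likely within or barely beyond the scatter, as a 1.3-fold higher number from compound 1 to compound 4 (0.13 log units; within the scatter). Compound 4 is estimated at 21000 nM, within 8000 nM to 50000 nM.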

Compound 4, half-maximal inhibitory concentration: 7860 nM
Beside the measured number, compound 4's estimate is 2.7-fold (0.43 log units) above it; measured number below the stated range.
By their numbers in this assay, from the lowest: compounds 4, 1 and 3 (each within the scatter of the next, the first and the last beyond it). At a limit, above all of these: compound 2.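

In this assay, ethyl on an aromatic carbon of the terminal phenyl, ortho to a large group, is tolerated, the step being a 2.0-fold lower number from compound 1 to compound 4 (0.30 log units; within the scatter). Substitution on this ring therefore need not weaken inhibition, as compound 2 alone had left it looking, and the 2-ethylphenyl urea separates from the cyclopentyl urea, where compound 1 did not, with a 2.3-fold lower number from compound 3 to compound 4 (0.37 log units; beyond the scatter). The step of an at least 5.0-fold lower number from compound 2 to compound 4 (0.70 log units; beyond the scatter) is only a bound, as compound 2 stands at a limit and gives no number: the limit of > 40000 nM in this assay, at which 1 of the 4 values shown sits.

On these data alone, it remains open whether ethyl itself matters or whether methyl, methoxy or a longer chain at this place would read the same. Also open, as far as these compounds go, is how ethyl would read elsewhere on the ring, and how an amine smaller than dimethylamino or a carboxylic acid would read there.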